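The source may report more compounds than this note shows. Statements on the series, on what has been measured and on what is new or still open speak of the compounds shown alone.

In an assay on HL-60 cells for inhibition of glutathione S-transferase P (Homo sapiens) (on this read-out higher numbers stand for weaker inhibition and lower numbers for stronger inhibition), compound 1 `C=C(C)C(=O)c1ccc(OCc2nc(-c3ccc(F)cc3)no2)cc1C` gives 3500 nM, and compound 2 `C=C(C)C(=O)c1ccc(OCc2nc(-c3ccc(C(F)(F)F)cc3)no2)cc1C` gives 3300 nM. Compound 2 differs from compound 1 by trifluoromethyl in place of fluoro on an aromatic carbon, and this change produced a 1.1-fold lower number from compound 1 to compound 2 (0.03 log units; within the scatter). Compound 3 `C=C(CC)C(=O)c1ccc(OCc2nc(-c3ccc(F)cc3)no2)c(Cl)c1Cl` gives 3900 nM in this assay; the difference between its core and the core of compound 1 is not broken down here. Compound 4 `C=C(CC)C(=O)c1ccc(OCc2nc(-c3ccc(C(F)(F)F)cc3)no2)c(Cl)c1Cl` has not been measured; it differs from compound 3 by trifluoromethyl in place of fluoro on an aromatic carbon, the same change that separates compound 2 from compound 1. Since that change gave a 1.1-fold lower number from compound 1 to compound 2 (0.03 log units; within the scatter), a similar small step is expected here, and the estimated step is a 1.1-fold lower number from compound 3 to compound 4 (0.03 log units; within the scatter). Compound 4 is therefore expected to give about 3600 nM in this assay, with the estimate spanning 1800 nM to 7500 nM.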

Compound 4, half-maximal inhibitory concentration: > 40000 nM
Compound 4 was reported as a limit; the forecaster's own chance of this, stated with the estimate: 5%; middle value at least 11-fold (1.04 log units) away from the limit.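

On the core of compound 3, trifluoromethyl in place of fluoro gave an at least 10-fold higher number from compound 3 to compound 4 (1.01 log units; beyond the scatter), so the size of the step did not carry over from the core of compound 1: the same change on two cores in this assay, a 1.1-fold lower number (0.03 log units; within the scatter) from compound 1 to compound 2 and an at least 10-fold higher number (1.01 log units; beyond the scatter) from compound 3 to compound 4, at least 10-fold (1.03 log units) apart, beyond the scatter of two such steps. The value of compound 4 is a limit of the assay and not a number: the limit of > 40000 nM in this assay, at which 1 of the 4 values shown sits. The two cores differ in more than one place, so this pair shows that the step can depend on the core, but not which part of the core matters or how the change behaves on any other core.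

On these data alone, whether a nitrile, an amine or a carboxylic acid on the same aromatic carbon would give a measurable value on the core of compound 3 stays open. Also open, as far as these compounds go, is how the change behaves on a core that differs from that of compound 1 in one place only.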